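Permeability of a 2-methoxyphenoxy analogue: an expectation

The compounds below may be only part of what the source reports. "The series", "measured", "known", "first", "only" and "open" are said of these compounds alone.

Measured compounds:
Compound 1 `CN(C)c1cccc(Oc2ccc3c(NCCCNCc4ccco4)ccnc3c2)c1` gives 317 10^-6 cm/s.
Compound 2 `Fc1ccc(Oc2ccc3c(NCCCNCc4ccco4)ccnc3c2)cc1` gives 317 10^-6 cm/s.

Both values come from an ADME assay for permeability, using PAMPA, with a stated time of 30 min, at pH 7.4; a lower number here means that the compound crosses the layer more slowly, a higher number that the compound crosses the layer faster. Compound 2 stands level with compound 1 at the digits measured: the step of no change at the digits printed from compound 1 to compound 2 (within the scatter) lies within the scatter, although the two compounds differ by 4-fluorophenyl in place of 3-(dimethylamino)phenyl on an oxygen on an aromatic ring. Compound 3 `COc1ccccc1Oc1ccc2c(NCCCNCc3ccco3)ccnc2c1` has not yet been measured in this assay . It differs from compound 2 by 2-methoxyphenyl in place of 4-fluorophenyl on an oxygen on an aromatic ring, that is 4-fluorophenoxy to 2-methoxyphenoxy on the shared core.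

Going by the values given here, the only step that bears on this change is the one from compound 1 to compound 2, which exchanged one group on the same oxygen for a quite different one and produced no movement beyond the scatter. On that basis compound 3 is expected to stay near compound 2, with a step of no change at the digits printed from compound 2 to compound 3 (within the scatter) that should not exceed the scatter. The estimate for compound 3 in this assay is therefore 317 10^-6 cm/s, with a range from 180 10^-6 cm/s to 480 10^-6 cm/s.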

Compound 3, apparent permeability: 317 10^-6 cm/s
Compound 3: middle estimate and measured number agree at the digits printed, within the range that was stated.
By their numbers in this assay, from the lowest: compounds 1, 2 and 3 (each within the scatter of the next).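

In this assay, the change from 4-fluorophenyl to 2-methoxyphenyl on an oxygen on an aromatic ring gives no change at the digits printed from compound 2 to compound 3 (within the scatter), and the larger group, with its one hydrogen-bond acceptor where the 4-fluorophenyl has none, leaves the read-out where it was. Going by these compounds alone, the comparison with the dimethylamino-bearing group gives no change at the digits printed from compound 1 to compound 3 (within the scatter), so three different aryl groups have now been carried on this oxygen without any step beyond the scatter, which extends what the single earlier step could show. Nothing at hand explains why these exchanges leave the value unmoved.

All three groups are six-membered aromatic rings of carbon joined through the same oxygen, so the compounds leave open whether a group of another kind, such as a carboxylic acid on that ring or a saturated cyclohexyl in its place, would hold the value as well. They also leave open whether the flat result would survive a change elsewhere, such as a longer chain on the shared core or a replacement for the furan ring.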